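Sulfonamide to amide swap on the shared core: clearance notes

The source may hold more compounds than are shown below. What is called first, only, known or untested is meant among the compounds shown, and "the series" means these compounds.

Measured so far in an in vitro ADME assay on microsomes from liver (Homo sapiens) for metabolic stability; a higher number here means faster removal of the compound, a lower number slower removal:
compound 1 `CNS(=O)(=O)c1ccc(-c2cnc(N)c(-c3ccc(OC)nc3)c2)cc1` gives 9.6 mL.min-1.g-1
compound 2 `COc1ccc(-c2cc(-c3ccc(S(C)(=O)=O)cc3C(F)(F)F)cnc2N)cn1` gives < 7 mL.min-1.g-1, a limit of the assay and not a number
compound 3 `COc1ccc(-c2cc(-c3ccc4nccn4c3)cnc2N)cn1` gives 12 mL.min-1.g-1

Compound 1 holds the lowest of the two numbers in this assay, with compound 3 sitting within the scatter of it, so no order between the two can be read. For compound 2 the assay reports only a limit, (the limit of < 7 mL.min-1.g-1 in this assay, at which 1 of the 3 values shown sits). Compound 4 `COc1ccc(-c2cc(-c3ccc(C(=O)N(C)C)cc3)cnc2N)cn1` is not yet measured; it differs from compound 1 by dimethylcarbamoyl in place of methylsulfamoyl on an aromatic carbon. Among the measured compounds shown here, no step between measured compounds is known, so this change has no precedent within the set. The step from compound 1 to compound 4 is expected to be small, a 1.3-fold higher number from compound 1 to compound 4 (0.10 log units; within the scatter), at most a modest rise and possibly none beyond the scatter. Compound 4 is estimated at 12 mL.min-1.g-1, in the range 7 mL.min-1.g-1 to 22 mL.min-1.g-1.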

Compound 4, intrinsic clearance in microsomes in the Homo sapiens assay: 11.1 mL.min-1.g-1
Compound 4: the middle estimate sits 1.1-fold (0.03 log units) above what was measured; the measured number falls inside the stated range.
By their numbers in the Homo sapiens assay, from the lowest: compounds 1, 4 and 3 (each within the scatter of the next). At a limit, below all of these: compound 2.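

Among the compounds shown here, in the Homo sapiens assay compound 1 gives 9.6 mL.min-1.g-1 and compound 4 gives 11.1 mL.min-1.g-1, and the swap at this aromatic carbon, the only step in the set so far, gives a 1.2-fold higher number from compound 1 to compound 4 (0.06 log units; within the scatter), so dropping the hydrogen-bond donor of methylsulfamoyl brings no readable change. In a physicochemical assay for lipophilicity, at pH 7.4 (on this read-out lower numbers stand for lower lipophilicity and higher numbers for higher lipophilicity), compound 1 gives 2.2 and compound 4 gives 2.1, and the same swap gives a number 0.10 log units lower from compound 1 to compound 4 (within the scatter), so neither read-out separates the two groups. Nothing at hand bears on the size of these steps.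

On these data alone, whether a carboxylic acid or an amine at this carbon would move the number in the Homo sapiens assay beyond the scatter stays open. A single step also cannot show how this swap behaves away from the shared core.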